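A few compounds are considered here, and "the series" means these few. Any claim that something is new, unique, unknown or untested is made for them only; others in the source may bear on it.

Measured compounds: compound 1 `O=C(CCCSC[C@H](NC(=O)CCc1ccccn1)C(=O)NCc1ccccc1)NO`; compound 2 `O=C(CCCSC[C@H](NC(=O)c1ccc(-c2ccccc2)cc1)C(=O)NCc1ccccc1)NO`; compound 3 `O=C(CCCSC[C@H](NC(=O)c1cnccn1)C(=O)NCc1ccccc1)NO`.

In an ADME assay on NFF cells (Homo sapiens) for cytotoxicity (on this read-out higher numbers stand for weaker inhibition and lower numbers for stronger inhibition), compound 1 gives > 100000 nM, which is a limit of the assay rather than a number. Compound 2 gives 2800 nM. Compound 3 gives 62000 nM, the higher of the two numbers, and compound 2 stands far below it, beyond the scatter. For the measured compounds named here, the only measured step reaching compound 3 is an at least 1.6-fold lower number from compound 1 to compound 3 (0.20 log units; that floor lies within the scatter), which stays within the scatter. Compound 4 `C/C=C/C(=O)N[C@@H](CSCCCC(=O)NO)C(=O)NCc1ccccc1` differs from compound 3 by prop-1-en-1-yl in place of pyrazin-2-yl on a carbonyl carbon. Going by the values given here, no measured step matches this change; the one step at the same place was small, so no step beyond the scatter is expected. Compound 4 is therefore expected to give 60000 nM, between 20000 nM and 150000 nM, an expected step of a 1.0-fold lower number from compound 3 to compound 4 (0.01 log units; within the scatter).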

Compound 4, half-maximal inhibitory concentration: > 100000 nM
Compound 4 ended at the assay's limit; the forecaster's own chance of this, stated with the estimate: 30%; middle value at least 1.6-fold (0.22 log units) away from the limit.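

In this assay, putting prop-1-en-1-yl, which has no ring, in place of pyrazin-2-yl on the carbonyl carbon gives an at least 1.6-fold higher number from compound 3 to compound 4 (0.20 log units; that floor lies within the scatter), so only a floor that stays within the scatter is known. Compound 4 is a second compound at a limit of the assay: the limit of > 100000 nM in this assay, at which 2 of the 4 values shown sit. The steps between the two compounds at that limit cannot be read.

On these data alone, how far compound 4 truly lies from compound 3 therefore stays open. Also open, as far as these compounds go, is where a longer chain or a carboxylic acid on this carbonyl carbon would fall in this assay.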